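The compounds below may be only part of what the source reports. "The series", "measured", "known", "first", "only" and "open" are said of these compounds alone.

- Compound 1 `CCN(CC)C(=O)Cn1c(=O)c(-c2ccc(OC)cc2)cc2c(OC)cc(OC)cc21`: 10000 nM
- Compound 2 `COc1ccc(-c2cc3c(OC)cc(OC)cc3n(C)/c2=N\Nc2ccccc2)cc1`: 10000 nM

Both compounds were tested in a functional assay on U-373MG ATCC cells for cytotoxicity against U373 MG (Homo sapiens), read by colorimetric assay and MTT assay; on this read-out higher numbers stand for weaker inhibition and lower numbers for stronger inhibition. Compound 2 stands level with compound 1 on this read-out, with no difference beyond the scatter. Compound 3 `COc1ccc(-c2cc3c(OC)cc(OC)cc3n(C)/c2=N\Nc2ccccn2)cc1` has not yet been measured. It has pyridin-2-yl in place of phenyl on an amine nitrogen, and the rest of compound 2 is unchanged: pyridin-2-yl in place of phenyl on an amine nitrogen. Among the measured compounds shown here, no measured pair here shows what such a change does in this assay, so its size cannot be read from the data. No step beyond the scatter is expected, and any small movement is thought more likely to be toward stronger inhibition because compound 2 gives 10000 nM, the same value as compound 1. The expected change is a 1.3-fold lower number from compound 2 to compound 3 (0.10 log units; within the scatter). Compound 3 is estimated at 8000 nM, with an expected range from 2000 nM to 12000 nM.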

Compound 3, half-maximal inhibitory concentration: 10000 nM
Estimate against measurement, compound 3: 1.3-fold (0.10 log units) below, within the range that was stated.
By their numbers in this assay, from the lowest: compounds 1, 2 and 3 (each within the scatter of the next).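

In this assay, pyridin-2-yl in place of phenyl on an amine nitrogen gives no change at the digits printed from compound 2 to compound 3 (within the scatter). Among the compounds shown here, this is the first step at this position that can be read, and it shows that the ring nitrogen entering with pyridin-2-yl, with the one hydrogen-bond acceptor counted for that group, leaves the read-out unmoved, with compound 3 at 10000 nM. No measurement shown here offers an explanation for this result.

The compounds shown leave open whether a different group on this amine nitrogen, such as a benzoic acid, an aminoalkyl group or a longer alkyl chain, would move the read-out away from the value of compound 2. They also leave open whether pyridin-2-yl in place of phenyl would give any step on a different core.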